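Swapping One Group on Compound 2

The compounds below may be only part of what the source reports. "The series", "measured", "known", "first", "only" and "open" are said of these compounds alone.

Compound 1 `COc1ccc(C(=O)/C=C/c2ccc(N(C)C)cc2)c2c1C=CC(C)(C)O2`: 730 nM
Compound 2 `COc1ccc(/C=C/C(=O)c2ccc(OC)c3c2OC(C)(C)C=C3)cn1`: > 10000 nM

These values come from a functional assay on HepG2 cells (Homo sapiens) for antiproliferative activity, read by MTT assay, with a stated time of 24 h; on this read-out higher numbers stand for weaker inhibition and lower numbers for stronger inhibition. Compound 2 reads > 10000 nM, which is a limit and not a number, so it stands at the limit of > 10000 nM in this assay, at which 1 of the 2 values shown sits. For the measured compounds named here, the only measured step is an at least 13-fold higher number from compound 1 to compound 2 (1.13 log units; beyond the scatter), and it changes the same place. Compound 3 `COc1ccc(C(=O)/C=C/c2ccc(Cl)c(Cl)c2)c2c1C=CC(C)(C)O2` brings this change: 3,4-dichlorophenyl in place of 6-methoxypyridin-3-yl on a double-bonded chain carbon bound to a double-bonded chain carbon. Like compound 1 at 730 nM, compound 3 has a ring of carbon only at this place, so stronger inhibition than in compound 2 is expected. The expected step is an at least 4.0-fold lower number from compound 2 to compound 3 (0.60 log units; beyond the scatter). For compound 3 the estimated value is 2500 nM, with an expected range of 500 nM to 10000 nM.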

Compound 3, half-maximal inhibitory concentration: > 10000 nM
Compound 3 gave a limit, no number; the forecaster's own chance of this, stated with the estimate: 20%; middle value at least 4.0-fold (0.60 log units) away from the limit.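

In this assay, compound 3 gives > 10000 nM, which is a limit and not a number. Putting 3,4-dichlorophenyl in place of 4-(dimethylamino)phenyl brings an at least 13-fold higher number from compound 1 to compound 3 (1.13 log units; beyond the scatter), so a ring of carbon only at this place does not by itself keep the stronger inhibition. The step between compound 2 and compound 3 cannot be read, as both values are limits: the limit of > 10000 nM in this assay, at which 2 of the 3 values shown sit.

Of the compounds shown, only compound 1 gives a number. As far as these compounds go, whether that needs the dimethylamino group in particular stays open, and a primary amine or a plain phenyl ring at this place could help to tell.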